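A few compounds are considered here, and "the series" means these few. Any claim that something is new, unique, unknown or untested is made for them only; others in the source may bear on it.

In a functional assay on C32 cells (Homo sapiens) for antiproliferative activity, read by WST assay, with a stated time of 72 h (a lower number here means a stronger inhibitor, a higher number a weaker inhibitor), compound 1 (`CCN(CC)CC#CCSc1nc2c(c(=O)[nH]c(=O)n2C)n1C`) gives 26400 nM. Compound 2 (`CCN(CC)CC#CCSc1nc(SCC#CCN(CC)CC)c2c(ncn2C)n1`) gives 23900 nM, level with compound 1 within the scatter, while compound 3 (`Cn1cnc2nc(SCC#CCN3CCCC3)nc(SCC#CCN3CCCC3)c21`) gives 6810 nM, a lower number beyond the scatter. Compound 1 therefore sits at the weak end of this small set, alongside compound 2.

Compound 4 (`Cn1c(SCC#CCN2CCCCC2)nc2c1c(=O)[nH]c(=O)n2C`) keeps the core of compound 1 and differs only on a saturated chain carbon bound to a triple-bonded carbon, where piperidin-1-yl stands in place of diethylamino: piperidin-1-yl in place of diethylamino on a saturated chain carbon bound to a triple-bonded carbon.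

Going by the values given here, no pair of measured compounds isolates this change, so the data give no direct size for it. Among the compounds with values here, the only guide is the spread of the three values, with compound 3 at 6810 nM marking the low end. A small move towards a lower number is expected in this assay, possibly no larger than the scatter, and the expected step is a 1.6-fold lower number from compound 1 to compound 4 (0.19 log units; within the scatter). The estimated value for compound 4 is 17000 nM, with an expected range of 8000 nM to 33000 nM.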

Compound 4, half-maximal inhibitory concentration: 355000 nM
Estimate against measurement, compound 4: 21-fold (1.32 log units) below, outside the stated range (above it).
By their numbers in this assay, from the lowest: compound 3; then compounds 2 and 1 (each within the scatter of the next); then compound 4.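

In this assay, the step gives this position its first direct reading: a 13-fold higher number from compound 1 to compound 4 (1.13 log units; beyond the scatter). The group on a saturated chain carbon bound to a triple-bonded carbon therefore matters strongly on the core of compound 1, and piperidin-1-yl is clearly not tolerated as well as diethylamino, even though the two groups have the same counts of hydrogen-bond donors and acceptors and neither carries a net charge. Nothing available accounts for the size of this step.

On these data alone, it remains open whether the loss follows from closing the ring or from the added carbon, and whether the same change would have a similar effect on a different core. Dimethylamino or morpholin-4-yl at this place on the core of compound 1 would help to separate these readings.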